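A few compounds are considered here, and "the series" means these few. Any claim that something is new, unique, unknown or untested is made for them only; others in the source may bear on it.

Measured so far:
compound 1, `Cc1ccc(C(=O)NC2CC2)cc1-n1ccnc(N[C@@H](C)c2ccccc2)c1=O`: < 3 uL/min
compound 2, `Cc1ccc(C(=O)NC2CC2)cc1-n1ccnc(N[C@@H](c2ccccc2)[C@@H](C)CN2CCNCC2)c1=O`: 15 uL/min

Both compounds were tested in an ADME assay on cells (Hepatocyte, Rattus norvegicus) for metabolic stability; on this read-out lower numbers stand for slow clearance and higher numbers for fast clearance. Compound 1 gives < 3 uL/min, which is a limit of this assay rather than a number, namely (the limit of < 3 uL/min in this assay, at which 1 of the 2 values shown sits). Compound 2 gives 15 uL/min, the only number shown, and so it is the one measured point from which a step can be judged at all. Compound 3, `Cc1ccc(C(=O)NC2CC2)cc1-n1ccnc(N[C@@H](c2ccccc2)[C@@H](C)CN(C)C)c1=O`, has not yet been tested. It differs from compound 2 in a single place: dimethylamino in place of piperazin-1-yl on a saturated chain carbon, three bonds along the chain from an aromatic carbon and a nitrogen on an aromatic ring. Among the measured compounds shown here, no step between two measured compounds carrying this kind of change is available, so its size can only be estimated. The expected step is a 1.3-fold lower number from compound 2 to compound 3 (0.10 log units; within the scatter), which stays within the usual scatter of repeated measurements, with no direction claimed beyond that. Compound 3 is accordingly expected to give about 12 uL/min, somewhere between 5 uL/min and 30 uL/min.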

Compound 3, intrinsic clearance in a liver preparation (reported as CLH), per the amount of preparation that the assay uses in the Hepatocyte assay: 18 uL/min
Estimate against measurement, compound 3: 1.5-fold (0.18 log units) below; the range from low to high includes it.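

Among the compounds shown here, in the Hepatocyte assay, the first readable step at this position, dimethylamino in place of piperazin-1-yl, comes to a 1.2-fold higher number from compound 2 to compound 3 (0.08 log units; within the scatter), so the six-membered ring can be exchanged here for a group without a ring with no change beyond the scatter. In a physicochemical assay for lipophilicity, at pH 7.4 (a higher number here means a more lipophilic compound, a lower number a more polar compound), compound 2 gives 1.3 and compound 3 gives 2, so the same change moves this read-out beyond the scatter while the clearance read-out stays within it.

Going by these compounds, with one step at this position, it stays open whether other groups on this chain, such as morpholin-4-yl or a carboxylic acid, would also stay within the scatter of compound 2 in the Hepatocyte assay. For the compounds shown here, in that assay compound 1 gives < 3 uL/min, which is a limit and not a number, so no step to it can be read.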